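This account rests on a few compounds, and the source may have more. Where it says the series, first, only, none or still open, it means among the compounds named here.

Measured so far: compound 2 `COc1ccc(/C=C/C(=O)Nc2cc3c(Nc4ccc(F)c(Cl)c4)ncnc3cc2O[C@H]2CCOC2)c(OC)c1OC` gives 7670 nM; compound 3 `COc1cc2ncnc(Nc3ccc(F)c(Cl)c3)c2cc1NC(=O)/C=C/c1ccc(F)cc1Cl` gives 32700 nM; compound 1 `COc1cc(/C=C/C(=O)Nc2cc3c(Nc4ccc(F)c(Cl)c4)ncnc3cc2OC)cc(OC)c1` was reported as "not active" (no number reported).

In a functional assay on PC-3 cells (Homo sapiens) for cytotoxicity, read by MTT assay, with a stated time of 72 h (on this read-out lower numbers stand for stronger inhibition and higher numbers for weaker inhibition), compound 2 holds the lowest number of the two reported, and the number for compound 3 lies beyond the usual scatter above it, while compound 1 gave no number at all. Compound 4 `COc1ccc(/C=C/C(=O)Nc2cc3c(Nc4ccc(F)c(Cl)c4)ncnc3cc2O[C@H]2CCOC2)cc1` has not yet been measured. It differs from compound 2 in one place: 4-methoxyphenyl in place of 2,3,4-trimethoxyphenyl on a double-bonded chain carbon bound to a double-bonded chain carbon. Three of the listed compounds are weak or inactive, so the change is expected to cost some activity. The step from compound 2 to compound 4 in this assay is estimated as a 2.1-fold higher number from compound 2 to compound 4 (0.32 log units; beyond the scatter), a loss somewhat beyond the scatter. Compound 4 is expected to give about 16000 nM, within a range from 4000 nM to 60000 nM.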

Compound 4, half-maximal inhibitory concentration: 2240 nM
For compound 4 the middle estimate is 7.1-fold (0.85 log units) above the measured one; measured number below the stated range.
By their numbers in this assay, from the lowest: compound 4; then compound 2; then compound 3.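

In this assay, 4-methoxyphenyl in place of 2,3,4-trimethoxyphenyl gives a 3.4-fold lower number from compound 2 to compound 4 (0.53 log units; beyond the scatter), a modest gain in strength. For the compounds shown here, this is the first comparison at this position, and it shows that the full 2,3,4-trimethoxyphenyl group is not required for activity here and that the smaller group does better. No measurement on hand explains the gain.

The compounds shown leave open whether the methoxy group of 4-methoxyphenyl matters at all. They also leave open how an amine or a carboxylic acid in its place would compare.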